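Swapping a Phenoxy for a Piperidine on a Shared Core

The source may hold more compounds than are shown below. What is called first, only, known or untested is meant among the compounds shown, and "the series" means these compounds.

Of the compounds shown here, three on one shared core have been tested in an ADME assay on Vero cells (Chlorocebus sabaeus) for cytotoxicity, with a stated time of 7 days; on this read-out lower numbers stand for higher toxicity in this test and higher numbers for lower toxicity in this test. Compound 1 `COc1cccc(CN2C(=O)CN(C(=O)c3cc4cc(OC)ccc4o3)C[C@@H]2CCc2ccccc2)c1` gives 4500 nM in this assay. Compound 3 `O=C(c1cc2cc(C3CC3)ccc2[nH]1)N1CC(=O)N(Cc2ccccc2)[C@@H](CN2CCC(F)CC2)C1` gives 24500 nM. Compound 2 `COc1ccc2[nH]c(C(=O)N3CC(=O)N(Cc4ccccc4)[C@@H](COc4ccccc4)C3)cc2c1` reaches only the limit of this assay, reported as > 10000 nM, so no number exists for it; the limit of > 10000 nM in this assay, at which 1 of the 3 values shown sits, marks where it stands. Compound 4 `COc1ccc2[nH]c(C(=O)N3CC(=O)N(Cc4ccccc4)[C@@H](CN4CCC(C(C)C)CC4)C3)cc2c1` remains to be measured, and it differs from compound 2 by 4-isopropylpiperidin-1-yl in place of phenoxy on a saturated chain carbon bound to a saturated ring carbon. Because compound 2 sits at the limit of > 10000 nM in this assay, at which 1 of the 3 values shown sits, the size of this step cannot be read from measured pairs; the expected change is a step that the limit leaves unreadable from compound 2 to compound 4, a shift at the edge of the usual scatter. Compound 4 is therefore estimated to give 12000 nM, with a likely range from 4000 nM to 40000 nM.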

Compound 4, half-maximal cytotoxic concentration: 3800 nM
Compound 4: the middle estimate sits 3.2-fold (0.50 log units) above what was measured; measured number outside the range, below it.
By their numbers in this assay, from the lowest: compounds 4 and 1 (each within the scatter of the next); then compound 3.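

In this assay, 4-isopropylpiperidin-1-yl in place of phenoxy on a saturated chain carbon bound to a saturated ring carbon brings an at least 2.6-fold lower number from compound 2 to compound 4 (0.42 log units; beyond the scatter). This shows that a change at this place alone can move the read-out towards higher toxicity in this test. The true size of the step stays unknown because compound 2 has only a limit and not a number: the limit of > 10000 nM in this assay, at which 1 of the 4 values shown sits.

As far as these compounds go, how a plain piperidin-1-yl or a morpholin-4-yl would read at this place remains open. So does whether the ring or its isopropyl group carries the step.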